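Carbamoyl in place of the sulfoximine on the shared core

The source may report more compounds than this note shows. Statements on the series, on what has been measured and on what is new or still open speak of the compounds shown alone.

In a functional assay on MIA PaCa-2 cells (Homo sapiens) for inhibition, read by MTT assay, with a stated time of 3 days (on this read-out lower numbers stand for stronger inhibition and higher numbers for weaker inhibition), compound 2 `CCOC(=O)[C@@H]1CCCN(S(=O)(=O)c2ccc(S(=N)(=O)N(CC)CC)cc2)C1` gives 900 nM, the higher of the two numbers in hand. Compound 1 `CCOC(=O)[C@@H]1CCCN(S(=O)(=O)c2ccc(S(=O)(=O)N(CC)CC)c(F)c2)C1` gives 200 nM in this assay, and the gap between the two lies beyond the scatter. Compound 3 `CCOC(=O)[C@@H]1CCCN(S(=O)(=O)c2ccc(C(=O)N(CC)CC)cc2)C1` differs from compound 2 by a group of 7 heavy atoms (5 carbon, 1 nitrogen, 1 oxygen; no ring) in place of a group of 8 heavy atoms (4 carbon, 2 nitrogen, 1 oxygen, 1 sulfur; no ring), on an aromatic carbon. For the measured compounds named here, no measured pair shows this change, and the expected step from compound 2 to compound 3 is a 1.5-fold lower number from compound 2 to compound 3 (0.18 log units; within the scatter), small and not beyond the scatter. Compound 3 is estimated at 600 nM, with a range from 150 nM to 2500 nM.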

Compound 3, half-maximal inhibitory concentration: 100 nM
Compound 3: the middle estimate sits 6.0-fold (0.78 log units) above what was measured, and the stated range ends above it.
By their numbers in this assay, from the lowest: compounds 3 and 1 (each within the scatter of the next); then compound 2.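

In this assay, diethylcarbamoyl in place of the sulfoximine, on an aromatic carbon para to a large group, gives a 9.0-fold lower number from compound 2 to compound 3 (0.95 log units; beyond the scatter) and so shows that this position is sensitive to the group it carries. The earlier pair differed in more than one place and could not show this. Nothing on hand bears on the origin of this step.

Still open, from the compounds shown here alone, is whether the step depends on the two ethyl groups, which a dimethylcarbamoyl group would probe. Also open, going by these compounds, is whether it persists with a carboxylic acid in place of the ethyl ester.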